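This account rests on a few compounds, and the source may have more. Where it says the series, first, only, none or still open, it means among the compounds named here.

Compound 1 `COc1ccc([C@H]2CC(=O)N(c3cccc(NS(=O)(=O)c4cc(C)ccc4OC)c3)C2)cc1OC1CCCC1`: > 10000 nM
Compound 2 `COc1ccc([C@H]2CC(=O)N(c3cccc(NS(=O)(=O)c4ccccc4F)c3)C2)cc1OC1CCCC1`: > 10000 nM
Compound 3 `COc1ccc([C@H]2CC(=O)N(c3cccc(NS(=O)(=O)c4cccc(Br)c4)c3)C2)cc1OC1CCCC1`: > 10000 nM

All three compounds were tested in a functional assay on HEK293 cells (Homo sapiens) for cytotoxicity; on this read-out higher numbers stand for lower toxicity in this test and lower numbers for higher toxicity in this test. Compound 3 gives > 10000 nM, which is a limit of the assay and not a number. The whole series stands at the limit of > 10000 nM in this assay, at which 3 of the 3 values shown sit.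

Compound 4 `COc1ccc([C@H]2CC(=O)N(c3cccc(NS(=O)(=O)c4cccc(C)c4)c3)C2)cc1OC1CCCC1` departs from compound 3 by a single change, methyl in place of bromo on an aromatic carbon, so that 3-bromophenyl becomes 3-methylphenyl. Three measured steps exchange the group on the sulfonyl sulfur: a step that the two limits leave unreadable from compound 1 to compound 2, a step that the two limits leave unreadable from compound 1 to compound 3 and a step that the two limits leave unreadable from compound 2 to compound 3. None of them has a readable size, but each joins two compounds resting at the same limit. The expectation therefore starts from compound 3 at > 10000 nM, again a limit. No shift beyond the usual scatter is expected in this assay, and the expected move is a step that the limit leaves unreadable from compound 3 to compound 4. For compound 4 the estimated value is 20000 nM. The expected range for compound 4 runs from 10000 nM to 50000 nM.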

Compound 4, half-maximal cytotoxic concentration: > 10000 nM
Compound 4 gave a limit, no number; the forecaster's own chance of this, stated with the estimate: 90%; the middle value lies beyond the limit too.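

In this assay compound 4 gives > 10000 nM, which is a limit and not a number. Its steps from compound 1, compound 2 and compound 3 cannot be read: the limit of > 10000 nM in this assay, at which 4 of the 4 values shown sit.

The compounds shown leave open whether any of these groups on the sulfonyl sulfur changes the value at all.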